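Removing one chloro group from a dichlorophenyl thiourea analogue

A few compounds are considered here, and "the series" means these few. Any claim that something is new, unique, unknown or untested is made for them only; others in the source may bear on it.

Of the compounds shown here, three have been measured. Compound 1 `COc1cc(/C=C/C(=O)C2=C(/C=C/c3ccc(O)c(OC)c3)NC(=O)NC2c2ccccc2)ccc1O` gives 50.2% in a functional assay, with a stated time of 20 min, tested at 50 uM; a lower number here means a weaker effect, a higher number a stronger effect of the compound at the concentration tested. Compound 2 `COc1cc(/C=C/C(=O)C2=C(/C=C/c3ccc(O)c(OC)c3)NC(=O)NC2c2ccccc2Cl)ccc1O` gives 56% in this assay, and the change hydrogen in place of chloro on an aromatic carbon makes the step of a number 5.8 percentage points lower from compound 2 to compound 1 (within the scatter). Compound 3 `COc1cc(/C=C/C(=O)C2=C(/C=C/c3ccc(O)c(OC)c3)NC(=S)NC2c2c(Cl)cccc2Cl)ccc1O` gives 50% in this assay; the difference between its core and the core of compound 2 is not broken down here. Compound 4 `COc1cc(/C=C/C(=O)C2=C(/C=C/c3ccc(O)c(OC)c3)NC(=S)NC2c2ccccc2Cl)ccc1O` is not yet measured; it differs from compound 3 by hydrogen in place of chloro on an aromatic carbon, the same kind of change as from compound 2 to compound 1, but here the place is also meta to a chloro group. Because the earlier step of a number 5.8 percentage points lower from compound 2 to compound 1 (within the scatter) stayed within the scatter, the step of a number 3 percentage points lower from compound 3 to compound 4 (within the scatter) is expected to be small as well. Compound 4 is therefore estimated at 47%, between 35% and 60%.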

Compound 4, a percentage reported as activity, at one concentration (the size of the read-out at that concentration, not a potency): 55.6%
Beside the measured number, compound 4's estimate is 8.6 percentage points below it; the range from low to high includes it.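

In this assay the change from 2,6-dichlorophenyl to 2-chlorophenyl gives a number 5.6 percentage points higher from compound 3 to compound 4 (within the scatter). Set beside the earlier step, hydrogen in place of chloro on an aromatic carbon reads alike on the two cores: the same change on two cores in this assay, a number 5.8 percentage points lower (within the scatter) from compound 2 to compound 1 and a number 5.6 percentage points higher (within the scatter) from compound 3 to compound 4, 11.4 percentage points apart, within the scatter of two such steps. This shows that the change stays within the scatter on both cores at the one concentration tested, but it does not show that the change is without effect in general, and the two steps give no direction that could be carried to another core.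

The compounds shown leave open how an amine, a nitrile or a carboxylic acid would read in place of chloro on this ring. They also leave open whether the same change would stay as small at other concentrations.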